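From 4-Chlorophenyl to 2-Fluorophenyl on the Shared Core

This account rests on a few compounds, and the source may have more. Where it says the series, first, only, none or still open, it means among the compounds named here.

Compound 3 `Clc1ccc(-c2cn3ccnc3c(-c3ccc4ncn(C5CCCCC5)c4c3)n2)cc1` gives 4.11% in a functional assay on NCI-H23 cells (Homo sapiens) for inhibition, read by sulforhodamine B assay, with a stated time of 48 h, tested at 10 uM; on this read-out higher numbers stand for more inhibition at the one concentration tested (going by the name of the read-out) and lower numbers for less inhibition. Compound 1 `O=Cc1ccc(-c2cn3ccnc3c(-c3ccc4ncn(C5CCCCC5)c4c3)n2)cc1` gives 54.5% in this assay, and compound 2 `Fc1ccc(-c2cn3ccnc3c(-c3ccc4ncn(C5CCCCC5)c4c3)n2)cc1` gives 2.36%. Compound 3 stands second highest of the three numbers: a number 1.8 percentage points higher from compound 2 to compound 3 (within the scatter), while a number 50.4 percentage points lower from compound 1 to compound 3 (beyond the scatter) and a number 52.1 percentage points lower from compound 1 to compound 2 (beyond the scatter). Compound 4 `Fc1ccccc1-c1cn2ccnc2c(-c2ccc3ncn(C4CCCCC4)c3c2)n1` differs from compound 3 by 2-fluorophenyl in place of 4-chlorophenyl on an aromatic carbon. Going by the values given here, the only measured step that bears on swapping one halogen for the other, a number 1.8 percentage points higher from compound 2 to compound 3 (within the scatter), lay within the scatter, and no measured step bears on a 2-fluorophenyl on this core. Compound 4 is therefore expected to show a number 0.9 percentage points higher from compound 3 to compound 4 (within the scatter), nothing beyond the scatter. Compound 4 is estimated at 5% in this assay, expected to fall between -5% and 20%.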

Compound 4, a percentage reported as inhibition, at one concentration (the size of the read-out at that concentration, not a potency): 4.16%
Compound 4: the middle estimate sits 0.8 percentage points above what was measured; the range from low to high includes it.
By their numbers in this assay, from the lowest: compounds 2, 3 and 4 (each within the scatter of the next); then compound 1.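

In this assay the fluorine's place on the phenyl ring makes no readable difference, with a number 1.8 percentage points higher from compound 2 to compound 4 (within the scatter) and the 4-chlorophenyl group likewise no different, with a number 0.1 percentage points higher from compound 3 to compound 4 (within the scatter). The 2-fluorophenyl group stays well apart from the 4-formylphenyl group, with a number 50.3 percentage points lower from compound 1 to compound 4 (beyond the scatter), so compound 1 remains alone among the four. No evidence is available to explain these numbers. The compounds shown leave open whether a carboxylic acid, an amide or an aminomethyl group in place of the formyl group would stay near compound 1 or join the halogen compounds.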